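Cytotoxicity notes on substituent variation at one aromatic carbon

A few compounds are considered here, and "the series" means these few. Any claim that something is new, unique, unknown or untested is made for them only; others in the source may bear on it.

Compound 1 `CCCCNc1nc(N)nc2c1ncn2/C=C1/CC1(CO)CO`, compound 2 `CCCSc1nc(N)nc2c1ncn2/C=C1/CC1(CO)CO` and compound 3 `CCOc1nc(N)nc2c1ncn2/C=C1/CC1(CO)CO` share one core and differ only in the group on a single aromatic carbon. In an ADME assay on HFF cells (Homo sapiens) for cytotoxicity, with a stated time of 8 days (on this read-out higher numbers stand for lower toxicity in this test and lower numbers for higher toxicity in this test), compound 1 gives > 300000 nM, which is a limit of the assay and not a number. Compound 2 likewise gives only the limit > 300000 nM. Compound 3 also gives only the limit > 300000 nM. All three values sit at the limit of > 300000 nM in this assay, at which 3 of the 3 values shown sit, so compound 3 stands at the limit itself, not at a number. The steps a step that the two limits leave unreadable from compound 1 to compound 2, a step that the two limits leave unreadable from compound 1 to compound 3 and a step that the two limits leave unreadable from compound 2 to compound 3 therefore have no readable size. Compound 4 `Nc1nc(SC2CCCC2)c2ncn(/C=C3/CC3(CO)CO)c2n1` differs from compound 3 by cyclopentylsulfanyl in place of ethoxy on an aromatic carbon. The step bearing most directly on it is a step that the two limits leave unreadable from compound 2 to compound 3, unreadable, so no step beyond the scatter in either direction can be expected in this assay. Compound 4 is expected to give 300000 nM, within 100000 nM to 300000 nM, most probably again as a limit. The step of a number no higher from compound 3 to compound 4 (the limit leaves the size open) is accordingly estimated as none.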

Compound 4, half-maximal cytotoxic concentration: > 300000 nM
Compound 4: only a limit was reported; the forecaster's own chance of this, stated with the estimate: 85%; the middle value sits exactly at the limit.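

Compound 4, like compound 1, compound 2 and compound 3, gives only a limit, so no step among these compounds can be read: the limit of > 300000 nM in this assay, at which 4 of the 4 values shown sit. The compounds shown leave open whether any group on this aromatic carbon gives a readable number in this assay.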